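Swapping cyclohexyl for 4-fluorophenyl on an isoxazole-bearing core

A few compounds are considered here, and "the series" means these few. Any claim that something is new, unique, unknown or untested is made for them only; others in the source may bear on it.

The series consists of three compounds sharing one core. Compound 1 `CC(C)n1nc(-c2cc(C3CCCCC3)on2)c2c(N)ncnc21` has been tested in an assay on BaF3 cells for inhibition of proto-oncogene tyrosine-protein kinase receptor Ret variant V804M (Homo sapiens), read by MTT assay, with a stated time of 48 h (a higher number here means a weaker inhibitor of growth, a lower number a stronger inhibitor of growth), and gives 4730 nM. Among the measured compounds shown here, this is the higher of the two numbers measured so far; compound 2 `Nc1ncnc2c1c(-c1cc(C3CC3)on1)nn2C1CCOCC1` gives 1930 nM in this assay, and the gap between the two values lies beyond the usual scatter. For the measured compounds named here, compound 2 differs from compound 1 in more than one place, so no single structural step links them.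

Compound 3 `CC(C)n1nc(-c2cc(-c3ccc(F)cc3)on2)c2c(N)ncnc21` has not yet been measured. Relative to compound 1 it carries 4-fluorophenyl in place of cyclohexyl on an aromatic carbon. Going by the values given here, there is no measured pair in this set in which only that group changes, so nothing in the data fixes the size or the direction of the step.

The author's expectation is that the exchange leaves the number near that of compound 1 or moves it modestly lower, with the estimated step from compound 1 to compound 3 being a 1.7-fold lower number from compound 1 to compound 3 (0.23 log units; within the scatter). Compound 3 is therefore estimated at 2800 nM in this assay, within a range of 700 nM to 11000 nM.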

Compound 3, concentration for 50% growth inhibition: > 10000 nM
Compound 3: a limit, no number; the forecaster's own chance of this, stated with the estimate: 5%; middle value at least 3.5-fold (0.55 log units) away from the limit.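

Compound 3 gives > 10000 nM in this assay, and that value is a limit of the assay, not a number: the limit of > 10000 nM in this assay, at which 1 of the 3 values shown sits. Even so, the direction of the change can be read, since 4-fluorophenyl in place of cyclohexyl gives an at least 2.1-fold higher number from compound 1 to compound 3 (0.32 log units; beyond the scatter), so on this aromatic carbon next to the ring oxygen the exchange weakens growth inhibition, and the step beyond the scatter has a lower bound but no fixed size. Among the compounds shown here, this is the first comparison that changes one place only, and it shows that the read-out responds to the group at this position, which compound 1 and compound 2 could not show, as they differ in more than one place.

The compounds shown do not separate the aromatic ring from its fluorine, so it stays open which part of 4-fluorophenyl goes with the weaker result. As far as these compounds go, how an unsubstituted phenyl, a piperidine ring carrying a basic amine or a longer alkyl chain would read at this position also remains open, as does the part played by the cyclopropyl of compound 2.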